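The source may report more compounds than this note shows. Statements on the series, on what has been measured and on what is new or still open speak of the compounds shown alone.

Two compounds from this series have been taken through an ADME assay for permeability, using PAMPA, with a stated time of 4 h, at pH 5.5; on this read-out lower numbers stand for lower permeability and higher numbers for higher permeability. Compound 1, `NCCCCN(C[C@H]1Cc2nccnc2CN1)[C@H]1CCCc2cccnc21`, gives 2 nm/s in this assay. Compound 2, `NC/C=C/CN(C[C@H]1Cc2ncccc2CN1)[C@H]1CCCc2cccnc21`, gives 2 nm/s in this assay, and at the digits reported it stands level with compound 1, the two values lying within the usual scatter of each other. For the measured compounds named here, the shared core is thus so far associated with low readings on this assay, and no step between measured compounds has yet been characterised.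

The next compound, compound 3, `c1cnc2c(c1)CN[C@@H](CN(CCCCNC1CCOCC1)[C@H]1CCCc3cccnc31)C2`, differs from compound 2 at one position: 3-((oxan-4-yl)amino)propyl in place of 3-aminoprop-1-en-1-yl on a saturated chain carbon bound to an amine nitrogen.

Going by the values given here, with no measured step to build on, the expectation rests on the two values in hand and on the nature of the change. The step from compound 2 to compound 3 is expected to be a 2.5-fold higher number from compound 2 to compound 3 (0.40 log units; beyond the scatter), modest and upward, though it could also fall within the scatter. On that basis compound 3 is estimated to give 5 nm/s in this assay, within a range from 1 nm/s to 25 nm/s.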

Compound 3, apparent permeability: 2 nm/s
For compound 3 the middle estimate is 2.5-fold (0.40 log units) above the measured one, within the range that was stated.
By their numbers in this assay, from the lowest: compounds 1, 2 and 3 (each within the scatter of the next).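

For the compounds shown here, the exchange of 3-aminoprop-1-en-1-yl for 3-((oxan-4-yl)amino)propyl on a saturated chain carbon bound to an amine nitrogen gives no change at the digits printed from compound 2 to compound 3 (within the scatter) in this assay, and this is the first step that can be read at this place. It shows that the group here can grow from 4 heavy atoms with no ring to 10 heavy atoms with a six-membered non-aromatic ring, and the double bond outside aromatic rings can go, while compound 3 still gives 2 nm/s, the same low reading as before. Nothing measured on these compounds accounts for this result.

This single step carries several differences at once, so it leaves open what the oxane ring, the extra amino nitrogen and the saturated chain each contribute on their own. It also leaves open whether any other group at this place, such as a carboxylic acid, a morpholine or a simple methyl, would lift the reading from this low level.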